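Adding a nitro group to compound 3

The source may report more compounds than this note shows. Statements on the series, on what has been measured and on what is new or still open speak of the compounds shown alone.

Measured compounds in a functional assay on PANC-1 cells (Homo sapiens) for antiproliferative activity, read by fluorescence and resazurin assay, with a stated time of 48 h (on this read-out lower numbers stand for stronger inhibition and higher numbers for weaker inhibition), are as follows
Compound 1 `Cc1noc(NS(=O)(=O)c2ccc(NC(=O)c3cc4ccc(O)cc4oc3=O)cc2)c1C` gives 16200 nM
Compound 2 `O=C(N/N=C/c1cccnc1)c1cc2ccc(O)cc2oc1=O` gives 2530 nM
Compound 3 `Cc1noc(NS(=O)(=O)c2ccc(NC(=O)c3cc4ccccc4oc3=O)cc2)c1C` gives 19900 nM

Compound 3 and compound 1 lie within the scatter of each other at the high end of these numbers, while compound 2 stands clearly lower, though its structure differs from theirs in more than one place. The next compound is compound 4 `Cc1noc(NS(=O)(=O)c2ccc(NC(=O)c3cc4cc([N+](=O)[O-])ccc4oc3=O)cc2)c1C` which differs from compound 3 by nitro in place of hydrogen on an aromatic carbon with the change made on a six-membered aromatic ring of carbon only, part of a fused or bridged system of two rings.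

Going by the values given here, only one measured step bears on this, and only loosely: a 1.2-fold higher number from compound 1 to compound 3 (0.09 log units; within the scatter) is a swap of hydrogen in place of hydroxy on an aromatic carbon and it stayed within the scatter. Among the compounds with values here, no measured step brings in nitro, so the data give no direct size for this change. Within the data shown here, with a 1.2-fold higher number from compound 1 to compound 3 (0.09 log units; within the scatter) as the only guide, no step beyond the scatter is expected in this assay in either direction, and the range is kept wide. For compound 4 the estimated value is 16000 nM with an expected range from 6000 nM to 40000 nM in this measurement. This estimate means an expected 1.2-fold lower number from compound 3 to compound 4 (0.09 log units; within the scatter) and the measurement is still to come.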

Compound 4, half-maximal inhibitory concentration: 11900 nM
The estimate for compound 4 lay 1.3-fold (0.13 log units) above the measured number; the measured number falls inside the stated range.
By their numbers in this assay, from the lowest: compound 2; then compounds 4, 1 and 3 (each within the scatter of the next).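

In this assay, nitro in place of hydrogen on the six-membered aromatic ring of carbon only gave a 1.7-fold lower number from compound 3 to compound 4 (0.22 log units; within the scatter), so a group of 3 heavy atoms with 2 hydrogen-bond acceptors and no donor was taken up at this position without a step beyond the scatter. With a 1.2-fold higher number from compound 1 to compound 3 (0.09 log units; within the scatter), this makes two single changes on this ring, the swap of hydroxy for hydrogen and now the nitro, and neither step lies beyond the scatter, which among compounds 1, 3 and 4 holds for a group of several heavy atoms as well as for a single oxygen-bearing group. Nothing measured here bears on why this step has the size it has.

From the compounds shown here alone, whether an amine or a carboxylic acid in place of the nitro would give a step beyond the scatter in this assay remains open, as does the effect of nitro on the other carbons of this ring. The compounds shown also leave open whether nitro in place of hydrogen on the core of compound 2, with its different side chain, would give a step of similar size.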